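A few compounds are considered here, and "the series" means these few. Any claim that something is new, unique, unknown or untested is made for them only; others in the source may bear on it.

Two measured compounds share a core of an unsaturated amide joined to a five-membered aromatic ring that carries a fluorophenyl group. Compound 1 is `C/C(=C\c1ccc(-c2ccc(F)cc2)o1)C(N)=O` and compound 2 is `C/C(=C\c1cc(-c2ccc(F)cc2)cs1)C(N)=O`. In a functional assay on MCF7 cells (Homo sapiens) for cytotoxicity, read by CCK-8 assay, with a stated time of 24 h (a higher number here means a weaker inhibitor, a lower number a stronger inhibitor), compound 1 gives 970 nM, and in this assay compound 2 gives 1440 nM. These two numbers lie within the usual scatter of each other, so the data show no difference between compound 1 and compound 2 that can be trusted.

Compound 3 is `C/C(=C\c1cc(-c2ccc(C(F)(F)F)cc2)cs1)C(N)=O`. It differs from compound 2 by trifluoromethyl in place of fluoro on an aromatic carbon. Going by the values given here, no measured pair in this set shows the effect of this change, so the expected step is taken as small: in this assay the step from compound 2 to compound 3 is expected to be a 1.3-fold higher number from compound 2 to compound 3 (0.10 log units; within the scatter), a shift not clearly beyond the scatter, leaning toward a somewhat higher number. Compound 3 is expected to give 1800 nM, with a likely range from 700 nM to 4500 nM.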

Compound 3, half-maximal inhibitory concentration: 50000 nM
The estimate for compound 3 lay 28-fold (1.44 log units) below the measured number; measured number above the stated range.
By their numbers in this assay, from the lowest: compounds 1 and 2 (each within the scatter of the next); then compound 3.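

The earlier compounds shown here all carry fluoro on the six-membered aromatic ring of carbon only, so they said nothing about how much this position matters. In this assay, trifluoromethyl in place of fluoro gives a 35-fold higher number from compound 2 to compound 3 (1.54 log units; beyond the scatter), which shows that a single substituent change on this aromatic carbon can weaken a compound sharply. No measurement among these data explains this loss of activity.

Going by these compounds alone, only this one pair reports on the position, so it remains open whether a chloro, a methoxy or an amine group there would stay close to compound 2 or fall away as trifluoromethyl does. On these data alone, it is also open whether the same exchange would have a similar effect on the core of compound 1, with its different five-membered aromatic ring.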